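Replacing a methylphenyl with a fluorophenyl in a quinoline amide series

The compounds below may be only part of what the source reports. "The series", "measured", "known", "first", "only" and "open" are said of these compounds alone.

Three compounds of a shared core were measured in a functional assay on MKN-45 cells (Homo sapiens) for cytotoxicity, read by MTT assay, with a stated time of 72 h; on this read-out higher numbers stand for weaker inhibition and lower numbers for stronger inhibition. Compound 1 `COc1cc2c(Oc3ccc(NC(=O)c4cc(-c5ccccc5C)ccn4)cc3F)ccnc2cc1OCCCN1CCN(C)CC1` gives 240 nM. Compound 2 `COc1cc2c(Oc3ccc(NC(=O)c4cc(-c5ccccc5)ccn4)cc3F)ccnc2cc1OCCCN1CCCC1` gives 210 nM. Among the measured compounds shown here, compound 3 `COc1cc2c(Oc3ccc(NC(=O)c4cc(-c5ccc(C)cc5)ccn4)cc3F)ccnc2cc1OCCCN1CCCC1` gives 440 nM, the highest of the three numbers; it sits within the scatter of compound 1 but beyond it from compound 2, since the single measured step, a 2.1-fold higher number from compound 2 to compound 3 (0.32 log units; beyond the scatter), arose from methyl in place of hydrogen on an aromatic carbon.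

Compound 4 `COc1cc2c(Oc3ccc(NC(=O)c4cc(-c5ccccc5F)ccn4)cc3F)ccnc2cc1OCCCN1CCCC1` differs from compound 3 by 2-fluorophenyl in place of 4-methylphenyl on an aromatic carbon. For the measured compounds named here, no measured step covers this exact exchange. Going by the values given here, the only step in hand, a 2.1-fold higher number from compound 2 to compound 3 (0.32 log units; beyond the scatter), shows that removing the methyl is linked to a modest fall in the number, and compound 1, which carries a phenyl with a substituent in a different position, gives 240 nM. The number for compound 4 is therefore expected to fall back toward that of compound 2, with an estimated step of a 1.8-fold lower number from compound 3 to compound 4 (0.25 log units; within the scatter). Compound 4 is estimated at 250 nM, within a range from 120 nM to 520 nM.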

Compound 4, half-maximal inhibitory concentration: 230 nM
The estimate for compound 4 lay 1.1-fold (0.04 log units) above the measured number; the measured number falls inside the stated range.
By their numbers in this assay, from the lowest: compounds 2, 4, 1 and 3 (each within the scatter of the next, the first and the last beyond it).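

In this assay, adding a substituent to the phenyl group does not always move the number beyond the scatter: fluoro in place of hydrogen gives a 1.1-fold higher number from compound 2 to compound 4 (0.04 log units; within the scatter), while methyl in place of hydrogen gave a 2.1-fold higher number from compound 2 to compound 3 (0.32 log units; beyond the scatter) in the earlier comparison. The direct exchange of 4-methylphenyl for 2-fluorophenyl gives a 1.9-fold lower number from compound 3 to compound 4 (0.28 log units; within the scatter), so this step alone does not separate the two groups, although only compound 3 lies beyond the scatter from compound 2. Nothing available explains these numbers.

Since 4-methylphenyl and 2-fluorophenyl differ in both the substituent and its place on the phenyl ring, the compounds shown cannot separate the effect of the atom from that of its position. They also leave open how chloro, methoxy or an amine on this phenyl ring would read in this assay on the same core.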